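This account rests on a few compounds, and the source may have more. Where it says the series, first, only, none or still open, it means among the compounds named here.

Compound 1 `COc1ccc(-c2cc(NC(=O)Nc3ccncc3)cc(C(F)(F)F)c2)cn1` gives > 300000 nM in a functional assay on SMMC-7721 cells (Homo sapiens) for inhibition, read by MTT assay, with a stated time of 48 h (on this read-out lower numbers stand for stronger inhibition and higher numbers for weaker inhibition), and this is a limit of the assay, not a number. The series offers little to go on here: the limit of > 300000 nM in this assay, at which 1 of the 2 values shown sits. Compound 2 `O=C(Nc1ccncc1)Nc1cc(-c2cncnc2)cc(C(F)(F)F)c1` gives 3730 nM in this assay. Going by the values given here, the only measured step, an at least 80-fold lower number from compound 1 to compound 2 (1.90 log units; beyond the scatter), is large, but it replaces a different group and leaves the pyridin-4-yl on the amide-type nitrogen untouched, so it bears only indirectly on what follows. Compound 3 `COc1ccc(-c2cc(NC(=O)Nc3nccs3)cc(C(F)(F)F)c2)cn1` keeps the rest of compound 1 and has 1,3-thiazol-2-yl in place of pyridin-4-yl on an amide-type nitrogen. Among the compounds with values here, no measured step covers this change, and a result still at the limit remains quite possible. The estimated step is an at least 5.0-fold lower number from compound 1 to compound 3 (0.69 log units; beyond the scatter), toward a lower number in this assay. Compound 3 is expected at about 60000 nM, with an estimated range of 8000 nM to 300000 nM.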

Compound 3, half-maximal inhibitory concentration: 36200 nM
Estimate against measurement, compound 3: 1.7-fold (0.22 log units) above; the measured number falls inside the stated range.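

Going by these compounds alone, with everything else held, the group on the amide-type nitrogen proves able to move the read-out in this assay: 1,3-thiazol-2-yl in place of pyridin-4-yl gives an at least 8.2-fold lower number from compound 1 to compound 3 (0.91 log units; beyond the scatter), whereas the only earlier step changed a different group. Compound 3 keeps the 6-methoxypyridin-3-yl group and still gives a measured number, 36200 nM. The size of the step can be read only as a bound, since compound 1 gives a limit of the assay and not a number: the limit of > 300000 nM in this assay, at which 1 of the 3 values shown sits.

Still open, on these data alone, is whether the change depends on the 1,3-thiazol-2-yl group itself; a phenyl or a 1,3-oxazol-2-yl on the same nitrogen would test this. Also open, as far as these compounds go, is whether this change, carried out with pyrimidin-5-yl in place of 6-methoxypyridin-3-yl, would give a step of similar size.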